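Shrinking the cyclic amine on the shared core

A few compounds are considered here, and "the series" means these few. Any claim that something is new, unique, unknown or untested is made for them only; others in the source may bear on it.

Values in an assay on cells with melanin-concentrating hormone receptor 1 (Homo sapiens) as the target, read by radioligand binding; a lower number here means a stronger inhibitor, a higher number a weaker inhibitor:
compound 1 `CCCOc1cccc2ccc(N)nc12`: 1100 nM
compound 2 `COC(C)(C)CCOc1cccc2ccc(N)nc12`: 132 nM
compound 3 `CC(CC(C)(C)C)Oc1cccc2ccc(N3CCCCC3)nc12`: > 2000 nM

Compound 3 stands at the limit of > 2000 nM in this assay, at which 1 of the 3 values shown sits. For compound 3 the reading > 2000 nM is a limit of the assay, not a number. Compound 4 `CC(CC(C)(C)C)Oc1cccc2ccc(N3CCCC3)nc12` differs from compound 3 by pyrrolidin-1-yl in place of piperidin-1-yl on an aromatic carbon. Going by the values given here, the single measured step, an 8.3-fold lower number from compound 1 to compound 2 (0.92 log units; beyond the scatter), alters the ether chain on the shared core and leaves the nitrogen substituent unchanged; compounds 1 and 2 carry no such ring there. Among the compounds with values here, no measured step bears on the ring-size change, and with compound 3 already at the limit no step beyond the scatter is expected in this assay, a step that the limit leaves unreadable from compound 3 to compound 4. Compound 4 is estimated at 3000 nM, within 800 nM to 10000 nM, with a fair chance that only a limit is again reported.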

Compound 4, half-maximal inhibitory concentration: > 2000 nM
Compound 4: only a limit was reported; the forecaster's own chance of this, stated with the estimate: 55%; the middle value lies beyond the limit too.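

Compound 3 and compound 4 both give only a limit in this assay, and no step can be read between them: the limit of > 2000 nM in this assay, at which 2 of the 4 values shown sit.

On these data alone, how pyrrolidin-1-yl and piperidin-1-yl compare on the shared core remains open.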